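A few compounds are considered here, and "the series" means these few. Any claim that something is new, unique, unknown or untested is made for them only; others in the source may bear on it.

Compound 2 `O=c1cc(-c2ccccc2)oc2cc(OCCCCNc3nc4ccc(Br)cc4s3)cc(O)c12` is the starting point of this step. In a physicochemical assay, read by spectrophotometry, with a stated time of 10 min (a lower number here means a stronger inhibitor, a higher number a weaker inhibitor), compound 2 gives 6.57 ug/mL. Its only comparator so far is compound 1 `O=c1cc(-c2ccccc2)oc2cc(OCCCCNc3nc4ccccc4s3)cc(O)c12`, which carries hydrogen where compound 2 carries bromo; in this assay compound 1 gives 8.57 ug/mL. The step of a 1.3-fold lower number from compound 1 to compound 2 (0.12 log units; within the scatter) shows that the two numbers lie within the scatter of each other, so neither compound can be called stronger.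

Compound 3 `O=c1cc(-c2ccccc2)oc2cc(OCCCCNc3nc4ccc(C(F)(F)F)cc4s3)cc(O)c12` changes the same position again: trifluoromethyl in place of bromo on an aromatic carbon. Among the compounds with values here, only one measured step bears on a substituent at this place, and it was a 1.3-fold lower number from compound 1 to compound 2 (0.12 log units; within the scatter), too small to count. A second swap at the same spot therefore gives no reason to expect a shift in this assay beyond the scatter in either direction. For compound 3 the estimated value in this assay is 6.5 ug/mL, with a range from 3.5 ug/mL to 12 ug/mL. The expected step of a 1.0-fold lower number from compound 2 to compound 3 (0.00 log units; within the scatter) is accordingly close to none.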

Compound 3, half-maximal inhibitory concentration: 4.95 ug/mL
For compound 3 the middle estimate is 1.3-fold (0.12 log units) above the measured one; low and high end bracket the measured number.
By their numbers in this assay, from the lowest: compounds 3, 2 and 1 (each within the scatter of the next).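

In this assay, the swap from bromo to trifluoromethyl gives a 1.3-fold lower number from compound 2 to compound 3 (0.12 log units; within the scatter), and the comparison with the unsubstituted parent gives a 1.7-fold lower number from compound 1 to compound 3 (0.24 log units; within the scatter). Until now, this position had offered a single step; there are now three substituents, hydrogen, bromo and trifluoromethyl, and none of the steps among them rises above the scatter, even though trifluoromethyl brings 4 heavy atoms where bromo brings 1. Nothing measured here offers an explanation for this flat result.

On these data alone, it remains open whether a quite different group at this place, such as an amine or a carboxylic acid, would give a step beyond the scatter. As far as these compounds go, it is equally open whether a longer chain joining the benzene-fused part to the shared core would shift the number more than these substituents do.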